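A few compounds are considered here, and "the series" means these few. Any claim that something is new, unique, unknown or untested is made for them only; others in the source may bear on it.

The measured compounds and their values in a functional assay on DU-145 cells (Homo sapiens) for inhibition, read by MTT assay, with a stated time of 24 h; on this read-out higher numbers stand for weaker inhibition and lower numbers for stronger inhibition:
Compound 1 `CCOC(=O)C1=Cc2ccccc2OC1(OCc1cn(-c2ccc(F)cc2)nn1)C(F)(F)F` gives 8900 nM.
Compound 2 `CCOC(=O)C1=Cc2ccccc2OC1(OCc1cc(-c2ccc(F)cc2F)no1)C(F)(F)F` gives only a limit of the assay, > 150000 nM.
Compound 3 `CCOC(=O)C1=Cc2ccccc2OC1(OCc1cn(CC(=O)Nc2cccc(Cl)c2)nn1)C(F)(F)F` gives 10100 nM.

Compound 2 stands apart from the other two. Among the measured compounds shown here, its result in this assay is a limit, not a number, and it is the one value among the three that sits at the limit of > 150000 nM in this assay, at which 1 of the 3 values shown sits. For the measured compounds named here, compound 1 and compound 3 both give numbers, and the one measured step between them, a 1.1-fold higher number from compound 1 to compound 3 (0.05 log units; within the scatter), is a change on an aromatic nitrogen of the core of compound 1.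

Compound 4 `CCOC(=O)C1=Cc2ccccc2OC1(OCc1cc(-c2ccc(Br)cc2)no1)C(F)(F)F` differs from compound 2 in one place: 4-bromophenyl in place of 2,4-difluorophenyl on an aromatic carbon. Going by the values given here, no measured step bears directly on this change, since the only step on record concerns a different ring of a different core, and compound 2 itself offers no number from which a step could be counted. Among the compounds with values here, the one measured step shows that a change of the pendant group left the number within the scatter, but it says nothing about the ring that is altered here.

Compound 4 is therefore expected to stay weak, most likely at or near a limit again, with an estimated value of 100000 nM, between 20000 nM and 200000 nM, which means an expected step of an at least 1.5-fold lower number from compound 2 to compound 4 (0.17 log units; that floor lies within the scatter).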

Compound 4, half-maximal inhibitory concentration: 71700 nM
For compound 4 the middle estimate is 1.4-fold (0.14 log units) above the measured one; measured number inside the range.
By their numbers in this assay, from the lowest: compounds 1 and 3 (each within the scatter of the next); then compound 4. At a limit, above all of these: compound 2.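

In this assay, 4-bromophenyl in place of 2,4-difluorophenyl, on an aromatic carbon of a five-membered aromatic ring with 1 nitrogen and 1 oxygen, gives an at least 2.0-fold lower number from compound 2 to compound 4 (0.32 log units; beyond the scatter). Among the compounds shown here, this is the first sign that the aryl group at this position can move the read-out, since the only earlier step concerned an aromatic nitrogen of a different core and stayed within the scatter. Compound 2 still has only a limit of the assay and not a number, so the true size of this step remains unknown: the limit of > 150000 nM in this assay, at which 1 of the 4 values shown sits.

The change removes two fluorine atoms and adds one bromine atom in a single swap, so the compounds shown leave open whether the difference follows from the bromine, from the loss of the 2-fluoro substituent, or from both, a question that a 4-fluorophenyl or 4-chlorophenyl group at this position would address. They also leave open how an unsubstituted phenyl ring or a phenyl ring carrying an amine or a carboxylic acid would read at this position, and whether 4-bromophenyl would have any comparable effect on the aromatic nitrogen of the core of compound 1.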